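Adding a fluoro group to compound 2

The source may hold more compounds than are shown below. What is called first, only, known or untested is meant among the compounds shown, and "the series" means these compounds.

Compound 1 `CC(=O)c1ccc(NC(=O)CSC(=S)N[C@H]2CCOC2=O)cc1` gives in a functional assay on EC9706 cells (Homo sapiens) for cytotoxicity, read by MTT assay, with a stated time of 72 h (a higher number here means a weaker inhibitor, a lower number a stronger inhibitor), a limit of > 128000 nM.
Compound 2 `O=C(CSC(=S)N[C@H]1CCOC1=O)Nc1ccc(C(=O)/C=C/c2ccccc2)cc1` gives in this assay 44900 nM.

Compound 2 holds the only number shown; the other value is a limit. Compound 3 `O=C(CSC(=S)N[C@H]1CCOC1=O)Nc1ccc(C(=O)/C=C/c2ccc(F)cc2)cc1` differs from it by fluoro in place of hydrogen on an aromatic carbon. For the measured compounds named here, the one measured step, an at least 2.8-fold lower number from compound 1 to compound 2 (0.45 log units; beyond the scatter), concerns a change at a different place and so bears only loosely on this one. Going by the values given here, with no measured step at the fluorinated ring, the expected shift in this assay is none beyond the scatter, giving an estimated step of a 1.3-fold lower number from compound 2 to compound 3 (0.11 log units; within the scatter). Compound 3 is therefore expected at 35000 nM, between 15000 nM and 90000 nM.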

Compound 3, half-maximal inhibitory concentration: 46100 nM
Beside the measured number, compound 3's estimate is 1.3-fold (0.12 log units) below it, and the stated range covers the measured number.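

In this assay, fluoro in place of hydrogen is the only change shown on the ring of the 2-phenylethenyl group, and at this place, para to a large group, it moves the number by no more than the scatter: a 1.0-fold higher number from compound 2 to compound 3 (0.01 log units; within the scatter). The 2-(4-fluorophenyl)ethenyl group also keeps the difference from the methyl group, with an at least 2.7-fold lower number from compound 1 to compound 3 (0.44 log units; beyond the scatter). The value of compound 1 is a limit: the limit of > 128000 nM in this assay, at which 1 of the 3 values shown sits.

On these data alone, what remains open is whether this place responds to any other group: a methoxy group, an amine or a carboxylic acid there could read differently.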